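From compound 1 to compound 4: a larger aromatic group

A few compounds are considered here, and "the series" means these few. Any claim that something is new, unique, unknown or untested is made for them only; others in the source may bear on it.

In a functional assay on K562 cells (Homo sapiens) for inhibition, read by MTT assay, with a stated time of 48 h (a higher number here means a weaker inhibitor, a lower number a stronger inhibitor), compound 1 (`CC(C)(C)OC(=O)N1C[C@@H](n2cc(-c3ccc(N)nc3)nn2)C[C@H]1C(=O)Nc1ccc(Cl)c(C(F)(F)F)c1`) gives 4710 nM. That number lies within the scatter of compound 3 (`O=C(Nc1n[nH]c2cc(-c3cn([C@@H]4CN[C@H](C(=O)Nc5ccc(Br)cc5)C4)nn3)ccc12)C1CC1`), which gives 8080 nM. Compound 2 (`Nc1ccc(-c2cn([C@@H]3CN[C@H](C(=O)Nc4ccc(Cl)c(C(F)(F)F)c4)C3)nn2)cn1`) gives 10400 nM. Compound 4 (`CC(C)(C)OC(=O)N1C[C@@H](n2cc(-c3ccc4nc(N)sc4n3)nn2)C[C@H]1C(=O)Nc1ccc(Cl)c(C(F)(F)F)c1`) keeps the tert-butoxycarbonyl group of compound 1 but differs elsewhere: a group of 10 heavy atoms (6 carbon, 3 nitrogen, 1 sulfur; one five-membered aromatic ring with 2 hetero atoms, one six-membered aromatic ring with 1 hetero atom) in place of a group of 7 heavy atoms (5 carbon, 2 nitrogen; one six-membered aromatic ring with 1 hetero atom), on an aromatic carbon. Within the data shown here, the only measured step, a 2.2-fold higher number from compound 1 to compound 2 (0.34 log units; beyond the scatter), puts hydrogen in place of tert-butoxycarbonyl on an amine nitrogen in a ring. That is a different place from the one changing here, so it gives no size for this swap, and no step beyond the scatter is expected in this assay. The estimated step is a 1.2-fold lower number from compound 1 to compound 4 (0.07 log units; within the scatter). For compound 4 the expected value is 4000 nM, with an estimated range of 1200 nM to 13000 nM.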

Compound 4, half-maximal inhibitory concentration: 10900 nM
Estimate against measurement, compound 4: 2.7-fold (0.44 log units) below; the measured number falls inside the stated range.
By their numbers in this assay, from the lowest: compounds 1, 3, 2 and 4 (each within the scatter of the next, the first and the last beyond it).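

In this assay, putting the larger group with two aromatic rings in place of 6-aminopyridin-3-yl, with tert-butoxycarbonyl kept, gives a 2.3-fold higher number from compound 1 to compound 4 (0.36 log units; beyond the scatter). This is the only step shown at this position, and it shows that the number there responds modestly, and upward, to this larger group. Nothing measured here accounts for the step.

As far as these compounds go, it remains open whether a plain phenyl ring or an aminopyrimidine at this position would shift the number. From the compounds shown here alone, it is also open whether the step would hold with hydrogen in place of tert-butoxycarbonyl.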